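The source may hold more compounds than are shown below. What is called first, only, known or untested is meant among the compounds shown, and "the series" means these compounds.

In a functional assay on A549 cells (Homo sapiens) for antiproliferative activity, read by MTT assay, with a stated time of 24 h (on this read-out higher numbers stand for weaker inhibition and lower numbers for stronger inhibition), compound 1 `O=C(NNc1cccc(Cl)c1)c1ccccc1NS(=O)(=O)c1cnc(O)nc1O` gives 5290 nM and compound 3 `Cc1ccccc1C(=O)NNC(=O)c1ccccc1NS(=O)(=O)c1cnc(O)nc1O` gives 5450 nM. These two stand level, with a 1.0-fold higher number from compound 1 to compound 3 (0.01 log units; within the scatter). Compound 2 `O=C(NNc1ccc(F)cc1)c1ccccc1NS(=O)(=O)c1cnc(O)nc1O` reads > 20000 nM, which is a limit of the assay and not a number. Compound 3 therefore sits with compound 1 at the stronger end of this small set, as an at least 3.6-fold lower number from compound 2 to compound 3 (0.56 log units; beyond the scatter) shows.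

Compound 4 `O=C(NNC(=O)c1ccccc1NS(=O)(=O)c1cnc(O)nc1O)c1ccccc1Cl` differs from compound 3 by one swap, chloro in place of methyl on an aromatic carbon, ortho to a large group. Within the data shown here, no measured step makes this exact swap, so the evidence is indirect. Compound 1 also carries a chloro on its ring and matches compound 3, which points to no step beyond the scatter in this assay. Still, an at least 3.7-fold higher number from compound 1 to compound 2 (0.57 log units; beyond the scatter) is a warning that a small change on a ring can weaken the read-out, so the range stays wider on the upper side. The expected result is a 1.0-fold higher number from compound 3 to compound 4 (0.00 log units; within the scatter). For compound 4 the estimated value is 5500 nM, with an expected range from 2200 nM to 14000 nM.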

Compound 4, half-maximal inhibitory concentration: 5290 nM
Compound 4: middle estimate off by 1.0-fold (0.02 log units), on the high side; low and high end bracket the measured number.
By their numbers in this assay, from the lowest: compounds 1, 4 and 3 (each within the scatter of the next). At a limit, above all of these: compound 2.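

Chloro in place of methyl on an aromatic carbon, ortho to a large group, leaves this assay level, with a 1.0-fold lower number from compound 3 to compound 4 (0.01 log units; within the scatter) as the step, so at this position the two groups cannot be told apart. The (2-chlorophenyl)carbonyl group of compound 4 also matches the 3-chlorophenyl group it can be set against, with no change at the digits printed from compound 1 to compound 4 (within the scatter) on record, so two different groups on that nitrogen give the same reading. In place of 4-fluorophenyl the same group gives an at least 3.7-fold lower number from compound 2 to compound 4 (0.57 log units; beyond the scatter) as a step, which starts from a limit of the assay and not a number: the limit of > 20000 nM in this assay, at which 1 of the 4 values shown sits.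

As far as these compounds go, whether a methoxy group, an amine or a carboxylic acid at this position would hold the reading level stays open. From the compounds shown here alone, what chloro and methyl each add over a plain hydrogen also stays open.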